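Swapping a bromophenyl for a fluorophenyl on a shared core

The source may report more compounds than this note shows. Statements on the series, on what has been measured and on what is new or still open speak of the compounds shown alone.

Compound 2 `Brc1ccc(-c2cn3ccnc3c(-c3ccc4ncn(C5CCCCC5)c4c3)n2)cc1` carries a 4-bromophenyl on its shared core. Among the measured compounds shown here, in a functional assay on MCF7 cells (Homo sapiens) for inhibition, read by sulforhodamine B assay, with a stated time of 48 h, tested at 10 uM (on this read-out higher numbers stand for more inhibition at the one concentration tested (going by the name of the read-out) and lower numbers for less inhibition), compound 2 gives 46.4%, the lower of the two numbers measured so far. For the measured compounds named here, its only measured neighbour is compound 1 `COc1ccc(-c2cn3ccnc3c(-c3ccc4ncn(C5CCCCC5)c4c3)n2)cc1`, which bears a methoxy in place of the bromo and in this assay gives 80.2%; the step of a number 33.8 percentage points lower from compound 1 to compound 2 (beyond the scatter) shows that exchanging the group on this phenyl ring can move the number a great deal.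

Compound 3 `Fc1ccccc1-c1cn2ccnc2c(-c2ccc3ncn(C4CCCCC4)c3c2)n1` has not yet been measured. It differs from compound 2 as follows: 2-fluorophenyl in place of 4-bromophenyl on an aromatic carbon. Going by the values given here, no measured step covers a fluoro group or the move from 4-bromophenyl to 2-fluorophenyl, so the one step available bears only indirectly on this change: it says the read-out is sensitive to what sits on this ring, but not in which direction the present swap will move it. Among the compounds with values here, a broad range is therefore expected, centred near the middle of the two known numbers. Compound 3 is estimated to give 50%, within 20% to 80%, which means an expected step of a number 3.6 percentage points higher from compound 2 to compound 3 (within the scatter).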

Compound 3, a percentage reported as inhibition, at one concentration (the size of the read-out at that concentration, not a potency): 11.2%
For compound 3 the middle estimate is 38.8 percentage points above the measured one, outside the stated range (below it).
By their numbers in this assay, from the lowest: compound 3; then compound 2; then compound 1.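

The new result shows that this position can pull the number down much further than the bromo group did: in this assay, the change to 2-fluorophenyl gives a number 35.2 percentage points lower from compound 2 to compound 3 (beyond the scatter), and the change from 4-methoxyphenyl gives a number 69 percentage points lower from compound 1 to compound 3 (beyond the scatter). The 4-bromophenyl and the 2-fluorophenyl have the same count of heavy atoms and the same counts of hydrogen-bond donors and acceptors, so these counts alone do not track the large drop between compound 2 and compound 3. No supporting measurement accompanies this drop to account for it.

Compound 3 differs from compound 2 in both the halogen and its place on the phenyl ring, so these compounds cannot say which of the two changes matters; a 4-fluorophenyl or a 2-bromophenyl would help to separate them. Also open, from the compounds shown here alone, is how a 4-aminophenyl or a phenyl ring carrying a carboxylic acid would behave here, and each number comes from a single concentration, so none of them is a potency.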